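Aryl swap at the saturated carbon on aromatic nitrogen

The source may hold more compounds than are shown below. What is called first, only, known or untested is meant among the compounds shown, and "the series" means these compounds.

Measured compounds:
compound 1 `Cc1ccc(Cn2cc(COc3ccc4c(=O)ccoc4c3)nn2)cc1` — > 100000 nM
compound 2 `O=c1ccoc2cc(OCc3cn(Cc4cccc(Br)c4)nn3)ccc12` — > 100000 nM

Both compounds were run in a functional assay on MDA-MB-231 cells (Homo sapiens) for cytotoxicity, read by MTT assay, with a stated time of 48 h; a lower number here means a stronger inhibitor, a higher number a weaker inhibitor. In this assay compound 1 gives > 100000 nM, which is a limit of the assay, not a number. In this assay compound 2 gives > 100000 nM, likewise a limit. Compound 1 thus sits at the assay limit, as the limit of > 100000 nM in this assay, at which 2 of the 2 values shown sit, shows for both values. The step that the two limits leave unreadable from compound 1 to compound 2 is the only one that bears on the new change, and it cannot be read. Compound 3 `O=c1ccoc2cc(OCc3cn(Cc4cccc([N+](=O)[O-])c4)nn3)ccc12` differs from compound 1 by 3-nitrophenyl in place of 4-methylphenyl on a saturated chain carbon bound to an aromatic nitrogen. With no readable step, no direction beyond the scatter is expected. Compound 3 is expected at 100000 nM, between 30000 nM and 300000 nM, a step of a number no higher from compound 1 to compound 3 (the limit leaves the size open).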

Compound 3, half-maximal inhibitory concentration: > 100000 nM
Compound 3 ended at the assay's limit; the forecaster's own chance of this, stated with the estimate: 75%; the middle value sits exactly at the limit.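

For the compounds shown here, compound 1, compound 2 and compound 3 all stand at the assay limit, and no step among them can be read. As far as these compounds go, what an aryl swap on a saturated chain carbon bound to an aromatic nitrogen does in this assay remains open.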